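Acetyl to oxime on the allyl series: paw edema inhibition

The compounds below may be only part of what the source reports. "The series", "measured", "known", "first", "only" and "open" are said of these compounds alone.

Measured so far:
compound 1 `CCn1c(SCC(=O)Nc2ccc(/C(C)=N/O)cc2)nnc1-c1ccc(OC)c(OC)c1`: 75%
compound 2 `C=CCn1c(SCC(=O)Nc2ccc(C(C)=O)cc2)nnc1-c1ccc(OC)c(OC)c1`: 70%

In a functional assay on the whole organism (strain albino) for inhibition, with Rattus norvegicus as the target, read by paw edema, with stated times of 30 min and 4 h, at a dose of 0.28 mmol/kg by the oral route (a lower number here means less inhibition, a higher number more inhibition at the dose given (going by the name of the read-out)), compound 2 gives 70%, the lower of the two numbers shown, while compound 1 gives 75%, a gap within the scatter. Among the measured compounds shown here, the two differ in more than one place, so no single step between them can be read.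

Compound 3 `C=CCn1c(SCC(=O)Nc2ccc(/C(C)=N/O)cc2)nnc1-c1ccc(OC)c(OC)c1` carries the change (a group of 4 heavy atoms (2 carbon, 1 nitrogen, 1 oxygen; no ring) in place of a group of 3 heavy atoms (2 carbon, 1 oxygen; no ring), on an aromatic carbon). Compound 1 already holds the entering group and sits within the scatter of compound 2, so no step beyond the scatter is expected from compound 2 to compound 3, an expected a number 3 percentage points higher from compound 2 to compound 3 (within the scatter). For compound 3 the estimate in this assay is 73%, between 60% and 85%.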

Compound 3, a percentage reported as inhibition, in the whole organism at one dose (the size of the read-out at that dose, not a potency): 79%
Estimate against measurement, compound 3: 6 percentage points below, and the stated range covers the measured number.
By their numbers in this assay, from the lowest: compounds 2, 1 and 3 (each within the scatter of the next).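

In this assay the exchange of acetyl for the oxime on the aromatic carbon para to a large group gives a number 9 percentage points higher from compound 2 to compound 3 (within the scatter) in the series carrying the allyl chain, so this position accepts either group at this dose. Vinyl in place of methyl on the saturated chain carbon bound to an aromatic nitrogen gives a number 4 percentage points higher from compound 1 to compound 3 (within the scatter) with the oxime held constant, so no difference appears at that place either. No measured evidence bears on the reason for these results.

On these data alone, whether an amine or a carboxylic acid on that aromatic carbon, or a longer chain on the aromatic nitrogen, would shift this assay beyond the scatter remains open.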